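The compounds below may be only part of what the source reports. "The series", "measured", "known", "first", "only" and "open" are said of these compounds alone.

Measured so far in an assay on membranes from CHO cells for displacement of a labelled ligand from adenosine receptor A1 (Homo sapiens), read by scintillation counting, with a stated time of 60 min, tested at 1 uM; on this read-out higher numbers stand for more inhibition at the one concentration tested (going by the name of the read-out) and lower numbers for less inhibition:
compound 1 `COc1ccc(-c2nc(SCC(=O)c3sc(-c4ccccc4)nc3C)nc(N)c2C#N)cc1` gives -4.6%
compound 2 `COc1ccc(-c2nc(C)c(C(=O)CSc3nc(N)c(C#N)c(-c4ccccc4)n3)s2)cc1` gives -2.8%
compound 3 `Cc1nc(-c2ccccc2)sc1C(=O)CSc1nc(N)c(C#N)c(-c2ccc(Cl)cc2)n1` gives -23%

Compound 3 stands lowest of the three numbers in this assay, with compound 1 its nearest neighbour and compound 2 the furthest, both gaps beyond the scatter. Going by the values given here, the one step in this assay that touches the same place, a number 18.4 percentage points lower from compound 1 to compound 3 (beyond the scatter), is modest and downward. Compound 4 `Cc1nc(-c2ccccc2)sc1C(=O)CSc1nc(N)c(C#N)c(-c2ccccc2)n1` differs from compound 3 by hydrogen in place of chloro on an aromatic carbon. Among the compounds with values here, no measured step shows removal of the chloro itself; compound 2, which also carries an unsubstituted phenyl at that place, gives a number near zero. A step of roughly the size seen between compound 1 and compound 3 is plausible, here expected upward, so that compound 4 is estimated at -8% with a range of -25% to 8%, an expected step of a number 15 percentage points higher from compound 3 to compound 4 (beyond the scatter).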

Compound 4, a percentage reported as inhibition, at one concentration (the size of the read-out at that concentration, not a potency): 9.5%
For compound 4 the middle estimate is 17.5 percentage points below the measured one; the whole stated range lies below it.
By their numbers in this assay, from the lowest: compound 3; then compounds 1 and 2 (each within the scatter of the next); then compound 4.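

Going from 4-chlorophenyl to phenyl gives a number 32.5 percentage points higher from compound 3 to compound 4 (beyond the scatter) in this assay, and replacing methoxy with hydrogen at the same place gives a number 14.1 percentage points higher from compound 1 to compound 4 (beyond the scatter), so the bare phenyl stands above both substituted forms. Replacing a methoxy at a different place in the molecule gives a number 12.3 percentage points higher from compound 2 to compound 4 (beyond the scatter), which leaves compound 4 highest of the four. Nothing measured here accounts for these steps.

Going by these compounds, it remains open whether fluoro, hydroxyl or an amine on this aromatic carbon would follow chloro and methoxy downward. A single-concentration percentage also leaves the potency of compound 4 open.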